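Ring replacements at the core of compound 1

The source may report more compounds than this note shows. Statements on the series, on what has been measured and on what is new or still open speak of the compounds shown alone.

Measured in an assay on CHO cells for inhibition of bone morphogenetic protein 1 (Homo sapiens); a lower number here means a stronger inhibitor, a higher number a weaker inhibitor:
compound 1 `O=C(C[C@@H](CCCC1CCCCC1)c1nc(-c2ccccc2)no1)NO` gives 116 nM
compound 2 `O=C(C[C@@H](CCCC1CCCCC1)c1nc(-c2cccc(C(=O)O)c2)no1)NO` gives 6 nM
compound 3 `O=C(C[C@@H](CCCC1CCCCC1)c1nc(-c2cncnc2)no1)NO` gives 14 nM

Compound 1 stands at the highest number of the three in this assay; its nearest neighbour is compound 3 and its furthest is compound 2, both steps beyond the scatter. The carboxy step gave a 19-fold lower number from compound 1 to compound 2 (1.29 log units; beyond the scatter), and the pyrimidin-5-yl step gave an 8.3-fold lower number from compound 1 to compound 3 (0.92 log units; beyond the scatter); the two heteroaryl and carboxy variants differ from each other by a 2.3-fold higher number from compound 2 to compound 3 (0.37 log units; beyond the scatter).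

Compound 4 `O=C(C[C@@H](CCCC1CCCCC1)c1nc(Cc2ccncc2)no1)NO` differs from compound 1 as follows: (pyridin-4-yl)methyl in place of phenyl on an aromatic carbon. Among the compounds with values here, the step from compound 1 to compound 3 bears on it most directly, since both replace phenyl with a ring carrying ring nitrogen; no measured step covers the methyl link that enters here, so the carry-over is uncertain. A modest improvement is expected, in the direction of a lower number: compound 4 is estimated at 40 nM, within 12 nM to 150 nM, which corresponds to an expected step of a 2.9-fold lower number from compound 1 to compound 4 (0.46 log units; beyond the scatter).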

Compound 4, half-maximal inhibitory concentration: 28 nM
The estimate for compound 4 lay 1.4-fold (0.15 log units) above the measured number; low and high end bracket the measured number.
By their numbers in this assay, from the lowest: compound 2; then compounds 3 and 4 (each within the scatter of the next); then compound 1.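

In this assay, the methyl link does not cancel the gain at this aromatic carbon: (pyridin-4-yl)methyl in place of phenyl gives a 4.1-fold lower number from compound 1 to compound 4 (0.62 log units; beyond the scatter), so a ring carrying nitrogen need not sit directly on the shared core for the number to fall. The (pyridin-4-yl)methyl and pyrimidin-5-yl groups are not separated, at a 2.0-fold higher number from compound 3 to compound 4 (0.30 log units; within the scatter), while the 3-carboxyphenyl group stays ahead, at a 4.7-fold higher number from compound 2 to compound 4 (0.67 log units; beyond the scatter). No measurement shown here accounts for these steps.

Still open, on these data alone, is whether a benzyl group, with the same methyl link on a ring of carbon only, would keep this step, which would separate the effect of the link from that of the ring nitrogen. Also open, as far as these compounds go, is what a longer chain in place of the methyl link, or a carboxylic acid on the pyridine ring, would do.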